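Phenoxy in place of methylsulfanyl: working notes on the series

The compounds below may be only part of what the source reports. "The series", "measured", "known", "first", "only" and "open" are said of these compounds alone.

Measured in a physicochemical assay for lipophilicity; a higher number here means a more lipophilic compound, a lower number a more polar compound:
compound 1 `COc1ccccc1C1=NC(c2ccccc2)CO1`: 3.76
compound 2 `CSc1ccccc1C1=NC(c2ccccc2)CO1`: 3.5

Compound 2 at 3.5 sits within the scatter of compound 1 at 3.76, so the two cannot be ranked in this assay. Going by the values given here, the only measured step, a number 0.26 log units lower from compound 1 to compound 2 (within the scatter), is methylsulfanyl in place of methoxy on an aromatic carbon, and it lies within the scatter.

The next structure is compound 3 `c1ccc(Oc2ccccc2C2=NC(c3ccccc3)CO2)cc1`, which carries phenoxy in place of methylsulfanyl on an aromatic carbon. The measured step bears on this change only in part. It exchanges one group for another with no ring on either side, whereas phenoxy brings a six-membered aromatic ring of carbon only. Among the compounds with values here, no measured step here adds such a ring, so the data do not fix the size of the change. A higher number is nevertheless expected, and a step well beyond the scatter. The expected step is a number 1.10 log units higher from compound 2 to compound 3 (beyond the scatter), and this remains an estimate. For compound 3 the estimated value is 4.6, with an expected range from 4.1 to 5.1.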

Compound 3, partition coefficient: 5.61
The estimate for compound 3 lay 1.01 log units below the measured number; the whole stated range lies below it.
By their numbers in this assay, from the lowest: compounds 2 and 1 (each within the scatter of the next); then compound 3.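

In this assay this position on an aromatic carbon now shows a step beyond the scatter, which the exchange of methoxy and methylsulfanyl did not: phenoxy in place of methylsulfanyl gives a number 2.11 log units higher from compound 2 to compound 3 (beyond the scatter) in a single change. Phenyl in place of methyl on an oxygen on an aromatic ring gives a number 1.85 log units higher from compound 1 to compound 3 (beyond the scatter). This step, which starts from the other compound without a ring at this position, is large as well, so a large step appears with either of those two compounds as the reference. Nothing at hand accounts for the size of these steps.

The compounds shown leave open whether the step belongs to the six-membered aromatic ring of carbon only or simply to the larger number of heavy atoms, a question that a longer chain such as butoxy or a saturated ring such as cyclohexyloxy at the same place would address. They also leave open how far the number would move, and in which direction, with an amine or a carboxylic acid on this aromatic carbon.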